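The compounds below may be only part of what the source reports. "The series", "measured", "known", "first", "only" and "open" are said of these compounds alone.

Among the compounds with values here, compound 1 `CN(C)c1nonc1/C(=N/O)Nc1ccc(F)c(Br)c1` is one of only two compounds measured so far in an assay for inhibition of Indoleamine 2,3-dioxygenase 1 (Homo sapiens); a lower number here means a stronger inhibitor, a higher number a weaker inhibitor. In this assay compound 1 gives > 5000 nM, which is a limit of the assay and not a number (the limit of > 5000 nM in this assay, at which 1 of the 2 values shown sits). Compound 2 `NCCNc1nonc1/C(=N/O)Nc1ccc(F)c(Br)c1` carries (2-aminoethyl)amino in place of dimethylamino on an aromatic carbon, and in this assay compound 2 gives 290 nM. Within the data shown here, the resulting step, an at least 17-fold lower number from compound 1 to compound 2 (1.23 log units; beyond the scatter), is the single measured step that bears on the change followed here. Compound 3 `CS(=O)(=O)NCCNc1nonc1/C(=N/O)Nc1ccc(F)c(Br)c1` has not yet been measured; its difference from compound 1 is (2-(methanesulfonamido)ethyl)amino in place of dimethylamino on an aromatic carbon. Compound 3 thus shares with compound 2 a chain of the (2-aminoethyl)amino type on the same aromatic carbon of the shared core, the terminal nitrogen now bearing a methanesulfonyl group. A large downward step is therefore expected from compound 1 to compound 3, an at least 25-fold lower number from compound 1 to compound 3 (1.39 log units; beyond the scatter), because an at least 17-fold lower number from compound 1 to compound 2 (1.23 log units; beyond the scatter) was itself large and well beyond the scatter. Compound 3 is estimated to give 200 nM, within a range from 60 nM to 700 nM.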

Compound 3, half-maximal inhibitory concentration: 100 nM
Compound 3: middle estimate off by 2.0-fold (0.30 log units), on the high side, and the stated range covers the measured number.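

In this assay the terminal nitrogen of the chain on this aromatic carbon does not have to stay an unsubstituted amine: methylsulfonyl in place of hydrogen on that nitrogen gives a 2.9-fold lower number from compound 2 to compound 3 (0.46 log units; beyond the scatter), a modest step that still lies beyond the scatter. The full replacement of dimethylamino by (2-(methanesulfonamido)ethyl)amino gives an at least 50-fold lower number from compound 1 to compound 3 (1.69 log units; beyond the scatter), so the large gain first seen with the (2-aminoethyl)amino chain is kept, and somewhat extended, once the end of that chain is capped. Compound 1 stands at a limit of the assay and not at a number, so the size of that step is only a bound: the limit of > 5000 nM in this assay, at which 1 of the 3 values shown sits.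

The compounds shown leave open whether an acetyl group or a sulfamide on the terminal nitrogen would serve as methylsulfonyl does, and whether a shorter or longer chain would keep the number. Equally open, going by these compounds, is what a simple methylamino group, or a chain joined through an oxygen atom on the same aromatic carbon, would give, so the part played by each piece of the chain cannot yet be separated.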